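The source may report more compounds than this note shows. Statements on the series, on what has been measured and on what is new or still open speak of the compounds shown alone.

Of the compounds shown here, three have so far been measured in an in vitro assay on BHK cells for inhibition of Glucagon receptor (Homo sapiens); on this read-out lower numbers stand for stronger inhibition and higher numbers for weaker inhibition. Compound 1 `CC(C)(C)[C@H]1CC[C@H](N(Cc2ccc(C(=O)NCCC(=O)O)cc2)C(=O)Nc2ccc(Cl)c(Cl)c2)CC1` gives 226 nM, compound 2 `O=C(O)CCNC(=O)c1ccc(CN(C(=O)Nc2cc(Cl)cc(Cl)c2)c2ccc(C3=CCCCC3)cc2)cc1` gives 27 nM, and compound 3 `CC(C)(C)C1CCC(N(Cc2ccc(C(=O)NCC(=O)O)cc2)C(=O)Nc2ccc(OC(F)(F)F)cc2)CC1` gives 1700 nM. Compound 3 thus shows the highest number of the three; its gap to compound 1 and its wider gap to compound 2 both lie beyond the scatter. Compound 4 `CC(C)(C)C1CCC(N(Cc2ccc(C(=O)NCC(=O)NO)cc2)C(=O)Nc2ccc(OC(F)(F)F)cc2)CC1` has not yet been measured. It differs from compound 3 by hydroxyamino in place of hydroxy on a carbonyl carbon. For the measured compounds named here, no step between measured compounds matches this change, so the expectation rests on compound 3 alone, whose value 1700 nM already stands high in this assay. A step of a 1.8-fold higher number from compound 3 to compound 4 (0.25 log units; within the scatter) is expected, a modest weakening that may not clear the scatter. Compound 4 is therefore estimated at 3000 nM, with a range from 900 nM to 12000 nM.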

Compound 4, half-maximal inhibitory concentration: 2960 nM
The estimate for compound 4 lay 1.0-fold (0.01 log units) above the measured number; measured number inside the range.
By their numbers in this assay, from the lowest: compound 2; then compound 1; then compounds 3 and 4 (each within the scatter of the next).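

In this assay, hydroxyamino in place of hydroxy on a carbonyl carbon gives a 1.7-fold higher number from compound 3 to compound 4 (0.24 log units; within the scatter), so compound 3 and compound 4 cannot be told apart on this read-out. For the compounds shown here, this is the first step read at this position, and it shows that carboxy and hydroxycarbamoyl read alike here, on this one core. Nothing measured accounts for this result. From the compounds shown here alone, whether a primary amide or a methyl ester on this carbonyl carbon would also read alike remains open. So does whether the same pair of groups would read alike on a longer chain, such as carboxyethyl.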